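The source may hold more compounds than are shown below. What is called first, only, known or untested is meant among the compounds shown, and "the series" means these compounds.

Measured so far:
compound 1 `CCCCOC(=O)CC1C(C(=O)OCCCC)=C(N)Oc2ccc(-c3cc(OC)cc(OC)c3)cc21` — 32000 nM
compound 2 `CCOC(=O)CC1C(C(=O)OCC)=C(N)Oc2ccc(-c3cc(F)cc(F)c3)cc21` — 35900 nM

In a functional assay on HL-60 cells (Homo sapiens) for cytotoxicity, read by CellTiter-Blue, with a stated time of 48 h (on this read-out higher numbers stand for weaker inhibition and lower numbers for stronger inhibition), compound 2 gives 35900 nM. Compound 1 gives 32000 nM in this assay, and the two numbers lie within the usual scatter of each other, so compound 2 does not stand apart from compound 1. Compound 3 `CCOC(=O)CC1C(C(=O)OCC)=C(N)Oc2ccc(-c3cccc(C(N)=O)c3)cc21` differs from compound 2 in one place: 3-carbamoylphenyl in place of 3,5-difluorophenyl on an aromatic carbon. Among the measured compounds shown here, no measured pair shows what such a swap does, so the size of the step is open. Compound 3 is expected to stay close to compound 2, with an estimated step of a 1.1-fold higher number from compound 2 to compound 3 (0.02 log units; within the scatter) not beyond the scatter. Compound 3 is estimated at 38000 nM, in a range from 12000 nM to 110000 nM.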

Compound 3, half-maximal inhibitory concentration: 5400 nM
Compound 3: middle estimate off by 7.0-fold (0.85 log units), on the high side; measured number outside the range, below it.
By their numbers in this assay, from the lowest: compound 3; then compounds 1 and 2 (each within the scatter of the next).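

In this assay, the group on this aromatic carbon clearly affects the read-out: 3-carbamoylphenyl in place of 3,5-difluorophenyl gives a 6.6-fold lower number from compound 2 to compound 3 (0.82 log units; beyond the scatter). The earlier compounds shown here offered no change in a single place, so they could not show this. No available measurement explains the step.

The change removes both fluorines and adds the carbamoyl group at once, so the two effects cannot be separated. On these data alone, how a carboxylic acid, an amine or a plain phenyl ring would compare at this position also remains open.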